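The source may report more compounds than this note shows. Statements on the series, on what has been measured and on what is new or still open speak of the compounds shown alone.

Of the compounds shown here, three that share one core have been measured in a functional assay on GTL 16 cells for antiproliferative activity against GTL 16 cell line (Homo sapiens), read by CCK-8 assay, with a stated time of 72 h; on this read-out lower numbers stand for stronger inhibition and higher numbers for weaker inhibition. Compound 1 `O=C(Nc1cccc(-c2oc3cc(-c4ccc(F)cc4)ccc3c(=O)c2O)c1)c1ccc(F)cc1` gives 14600 nM in this assay. Compound 2 `O=C(Nc1cccc(-c2oc3cc(-c4ccc(F)cc4)ccc3c(=O)c2O)c1)c1ccc(F)cc1F` gives 9640 nM in this assay, and the step of a 1.5-fold lower number from compound 1 to compound 2 (0.18 log units; within the scatter) lies within the scatter. Compound 3 `COc1ccccc1C(=O)Nc1cccc(-c2oc3cc(-c4ccc(F)cc4)ccc3c(=O)c2O)c1` gives 6370 nM in this assay, the lowest of the three numbers; the step of a 2.3-fold lower number from compound 1 to compound 3 (0.36 log units; beyond the scatter) is a modest one beyond the scatter, whereas the step of a 1.5-fold lower number from compound 2 to compound 3 (0.18 log units; within the scatter) stays within the scatter.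

Compound 4 `COc1ccc(C(=O)Nc2cccc(-c3oc4cc(-c5ccc(F)cc5)ccc4c(=O)c3O)c2)c(F)c1` has not yet been measured in this assay. It differs from compound 3 in one place: 2-fluoro-4-methoxyphenyl in place of 2-methoxyphenyl on a carbonyl carbon. The measured steps that bear on this are small: the step of a 1.5-fold lower number from compound 1 to compound 2 (0.18 log units; within the scatter) also sets a fluoro in place of hydrogen on an aromatic carbon, and the two exchanges of the aryl group on the carbonyl carbon, a 2.3-fold lower number from compound 1 to compound 3 (0.36 log units; beyond the scatter) and a 1.5-fold lower number from compound 2 to compound 3 (0.18 log units; within the scatter), were modest at most. Compound 4 is therefore expected to move only by the step of a 1.2-fold lower number from compound 3 to compound 4 (0.06 log units; within the scatter) in this assay, if at all. Compound 4 is estimated to give 5500 nM in this assay, within a range from 2500 nM to 13000 nM.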

Compound 4, half-maximal inhibitory concentration: 15300 nM
Compound 4: the middle estimate sits 2.8-fold (0.44 log units) below what was measured; measured number outside the range, above it.
By their numbers in this assay, from the lowest: compounds 3, 2, 1 and 4 (each within the scatter of the next, the first and the last beyond it).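

In this assay, for the compounds shown here, the exchange of 2-methoxyphenyl for 2-fluoro-4-methoxyphenyl on the carbonyl carbon gives a 2.4-fold higher number from compound 3 to compound 4 (0.38 log units; beyond the scatter) and is the first step at this place to raise the number beyond the scatter. The other two comparisons stay within the scatter: methoxy in place of fluoro gives a 1.6-fold higher number from compound 2 to compound 4 (0.20 log units; within the scatter) and 2-fluoro-4-methoxyphenyl in place of 4-fluorophenyl gives a 1.0-fold higher number from compound 1 to compound 4 (0.02 log units; within the scatter) without separating compound 4 from compound 1 or compound 2. A methoxy on this aryl group therefore does not by itself keep the lower number of compound 3, since compound 4 also carries one.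

Nothing shown gives a reason for the rise. Still open, going by these compounds, is how an amine or a carboxylic acid in place of the methoxy would read in this assay.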